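Removing the cinnamamide arm from compound 1

The compounds below may be only part of what the source reports. "The series", "measured", "known", "first", "only" and "open" are said of these compounds alone.

Compound 1 `COc1ccc(/C=C/C(=O)Nc2cc(C(=O)c3cc(OC)c(OC)c(OC)c3)cc(OC)c2OC)cc1` gives 11200 nM in a functional assay on HeLa cells (Homo sapiens) for cytotoxicity, read by MTT assay, with a stated time of 72 h; a higher number here means a weaker inhibitor, a lower number a stronger inhibitor. Among the three measured compounds it stands second highest; compound 2 `COc1ccc(/C=C/C(=O)Nc2cc(C(=O)c3cc(OC)c(OC)c(OC)c3)cc(OC)c2OC)cc1N` gives 15800 nM and compound 3 `C#CCOc1cccc(/C=C/C(=O)Nc2cc(C(=O)c3cc(OC)c(OC)c(OC)c3)cc(OC)c2OC)c1` gives 7300 nM, so all three lie close together. The steps of a 1.4-fold higher number from compound 1 to compound 2 (0.15 log units; within the scatter) and a 1.5-fold lower number from compound 1 to compound 3 (0.19 log units; within the scatter) are within the scatter, and only a 2.2-fold lower number from compound 2 to compound 3 (0.34 log units; beyond the scatter) is modest and beyond it.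

Compound 4 `COc1cc(C(=O)c2cc(OC)c(OC)c(OC)c2)cc(N)c1OC` differs from compound 1 by hydrogen in place of (2-(4-methoxyphenyl)ethenyl)carbonyl on a nitrogen on an aromatic ring. Among the compounds with values here, none of the measured steps bears on this change: each of them alters only the aryl end of the amide arm, leaving the arm itself in place. The measured steps show that changing that aryl end moves the number little, but they say nothing about what the whole arm contributes. The step of a 1.1-fold lower number from compound 1 to compound 4 (0.05 log units; within the scatter) is therefore expected to be uncertain in direction, with no change beyond the scatter as the central guess. For compound 4 the estimate in this assay is 10000 nM, with a wide range from 2000 nM to 50000 nM.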

Compound 4, half-maximal inhibitory concentration: 13500 nM
For compound 4 the middle estimate is 1.4-fold (0.13 log units) below the measured one; the range from low to high includes it.
By their numbers in this assay, from the lowest: compounds 3, 1, 4 and 2 (each within the scatter of the next, the first and the last beyond it).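

With the whole (2-(4-methoxyphenyl)ethenyl)carbonyl replaced by hydrogen on the nitrogen, this assay gives a 1.2-fold higher number from compound 1 to compound 4 (0.08 log units; within the scatter) and so no step beyond the scatter. The earlier compounds shown here altered only the aryl end of the arm, whereas this step shows that the full 12 heavy atoms of the acyl group, with its aromatic ring and both double bonds, can leave the nitrogen without a measurable shift in this one pair. No supporting measurement accounts for this result.

As far as these compounds go, whether the same holds for a small acyl group such as acetyl on that nitrogen, or for a saturated 3-(4-methoxyphenyl)propanoyl chain, remains open. Also open, from the compounds shown here alone, is whether changes elsewhere on the shared core, such as removing a methoxy group from the trimethoxyphenyl ring, would move the number beyond the scatter.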